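The source may hold more compounds than are shown below. What is called first, only, known or untested is meant among the compounds shown, and "the series" means these compounds.

Three compounds share one core and were tested in a functional assay on HL-60 cells (Homo sapiens) for antiproliferative activity, with a stated time of 24 h; on this read-out lower numbers stand for stronger inhibition and higher numbers for weaker inhibition. Compound 1, with the structure `NC(=O)c1c(NC(=O)c2ccccc2Cl)sc2c1CCN(Cc1ccccc1)C2`, gives 12000 nM in this assay. Compound 2, with the structure `NC(=O)c1c(NC(=O)c2ccccc2Cl)sc2c1CCN(Cc1ccccc1F)C2`, carries a fluoro in place of hydrogen on an aromatic carbon, the change marked as fluoro in place of hydrogen on an aromatic carbon, and in this assay compound 2 gives 21800 nM. That change produced a 1.8-fold higher number from compound 1 to compound 2 (0.26 log units; within the scatter). Compound 3, with the structure `NC(=O)c1c(NC(=O)c2ccccc2)sc2c1CCN(C(=S)Nc1ccccc1Cl)C2`, gives 13800 nM in this assay. How the core of compound 3 differs from the core of compound 1 is not broken down here; the two values of compound 1 and compound 3 lie close together.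

Compound 4, with the structure `NC(=O)c1c(NC(=O)c2ccccc2F)sc2c1CCN(C(=S)Nc1ccccc1Cl)C2`, is not yet measured. It differs from compound 3 by fluoro in place of hydrogen on an aromatic carbon, the same change as between compound 1 and compound 2, though cut one bond further out it reads benzoyl to (2-fluorophenyl)carbonyl rather than benzyl to 2-fluorobenzyl. Because the earlier pair showed a 1.8-fold higher number from compound 1 to compound 2 (0.26 log units; within the scatter), only a small shift is expected here as well. The expected step is a 1.4-fold higher number from compound 3 to compound 4 (0.16 log units; within the scatter). Compound 4 is therefore estimated to give about 20000 nM in this assay, with a likely range from 8000 nM to 50000 nM. This rests on a single earlier example, so the expectation is loose.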

Compound 4, half-maximal inhibitory concentration: 12500 nM
Compound 4: the middle estimate sits 1.6-fold (0.20 log units) above what was measured; the measured number falls inside the stated range.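

Putting a fluoro in place of hydrogen, here phenyl to 2-fluorophenyl, gives a 1.1-fold lower number from compound 3 to compound 4 (0.04 log units; within the scatter) in this assay. Set beside the earlier case, where benzyl became 2-fluorobenzyl on a different core, the two steps do not differ by more than repeated measurements of this kind would allow: the same change on two cores in this assay, a 1.8-fold higher number (0.26 log units; within the scatter) from compound 1 to compound 2 and a 1.1-fold lower number (0.04 log units; within the scatter) from compound 3 to compound 4, 2.0-fold (0.30 log units) apart, within the scatter of two such steps. This shows that in these two pairs the fluoro made no readable difference on either core, but it does not show that the change has the same effect on both, since a step lost in the scatter gives little to compare, and two pairs cannot set a rule for the series.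

The compounds shown leave open whether a different group in place of that hydrogen, such as a methoxy, an amine or a carboxylic acid, would move the number beyond the scatter on either core. They also leave open whether a larger change, such as a longer chain in place of the benzyl of compound 1, would carry over from one core to the other, which would be a firmer test of transfer than a pair of steps this small.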